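This account rests on a few compounds, and the source may have more. Where it says the series, first, only, none or still open, it means among the compounds named here.

Measured compounds in a functional assay on PC-3 cells (Homo sapiens) for inhibition, read by sulforhodamine B assay, with a stated time of 48 h; on this read-out higher numbers stand for weaker inhibition of growth and lower numbers for stronger inhibition of growth:
Compound 1 `Nc1cc(N)c2nc(-c3ccccc3)c(NCc3ccc(F)cc3)nc2c1` gives 3470 nM.
Compound 2 `COc1ccc(Sc2nc3cc(N)cc(N)c3nc2-c2ccccc2)cc1` gives 1740 nM.
Compound 3 `Nc1cc(N)c2nc(-c3ccccc3)c(Sc3ccc(Cl)c(Cl)c3)nc2c1` gives 3470 nM.

Compound 3 and compound 1 sit level at the digits shown, together the highest of the three numbers; compound 2 is the nearest to them, the two readings lying within the scatter of each other, so no order among the three can be claimed. The step to compound 4 `Nc1cc(N)c2nc(-c3ccccc3)c(Oc3ccc(F)cc3)nc2c1` is 4-fluorophenoxy in place of (3,4-dichlorophenyl)sulfanyl on an aromatic carbon. Among the compounds with values here, two measured steps bear on it: the exchange of the amine-linked group for the sulfur-linked group, no change at the digits printed from compound 1 to compound 3 (within the scatter), and the exchange of one aryl group on the sulfur for another, a 2.0-fold higher number from compound 2 to compound 3 (0.30 log units; within the scatter). Within the data shown here, neither reached beyond the scatter, and nothing among the measured compounds shows that an oxygen-linked 4-fluorophenyl group would behave otherwise. Compound 4 is therefore expected to give 3000 nM, with a range from 1200 nM to 8000 nM. This estimate means a step of a 1.2-fold lower number from compound 3 to compound 4 (0.06 log units; within the scatter), that is, no change expected beyond the scatter.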

Compound 4, concentration for 50% growth inhibition: 8320 nM
Beside the measured number, compound 4's estimate is 2.8-fold (0.44 log units) below it; measured number outside the range, above it.
By their numbers in this assay, from the lowest: compounds 2, 1 and 3 (each within the scatter of the next); then compound 4.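

In this assay, within the data shown here, this position is the first to give steps beyond the scatter: 4-fluorophenoxy gives a 2.4-fold higher number from compound 3 to compound 4 (0.38 log units; beyond the scatter) and a 4.8-fold higher number from compound 2 to compound 4 (0.68 log units; beyond the scatter) and also a 2.4-fold higher number from compound 1 to compound 4 (0.38 log units; beyond the scatter) in the modest range. The earlier exchanges among the amine-linked and sulfur-linked groups all stayed within the scatter, so compound 4 is the only one shown to separate from the others, with weaker inhibition of growth. Nothing available explains this separation.

The compounds shown leave open how much of the steps from the sulfur-linked compounds belongs to the oxygen link and how much to the ring substituents, since both differ in those pairs. They also leave open how a morpholine, a carboxylic acid or a longer alkyl chain would read on this aromatic carbon.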